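Side-chain changes and liver-cell cytotoxicity in the series

The source may hold more compounds than are shown below. What is called first, only, known or untested is meant among the compounds shown, and "the series" means these compounds.

The shared core carries varying groups on the saturated chain carbon bound to a saturated ring carbon. In an ADME assay on L02 cells (Homo sapiens) for cytotoxicity, read by MTT assay, with a stated time of 48 h (on this read-out lower numbers stand for stronger inhibition and higher numbers for weaker inhibition), compound 1 `CN(CCC#N)C[C@H]1CN(c2ccc(-n3cc(-c4ccccn4)cn3)c(F)c2)C(=O)O1` gives > 400 ug/mL, which is a limit of the assay and not a number. Compound 2 `O=C1CNC(=O)N1C[C@H]1CN(c2ccc(-n3cc(-c4ccccn4)cn3)c(F)c2)C(=O)O1` likewise gives > 400 ug/mL, again a limit. Among the compounds with values here, compound 3 `CN(C)S(=O)(=O)NC[C@H]1CN(c2ccc(-n3cc(-c4ccccn4)cn3)c(F)c2)C(=O)O1` gives 158 ug/mL, the only actual number among the three. The two readable steps towards it are an at least 2.5-fold lower number from compound 1 to compound 3 (0.40 log units; beyond the scatter) and an at least 2.5-fold lower number from compound 2 to compound 3 (0.40 log units; beyond the scatter); the step that the two limits leave unreadable from compound 1 to compound 2 cannot be read, since (the limit of > 400 ug/mL in this assay, at which 2 of the 3 values shown sit).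

Compound 4 `O=C(NC[C@H]1CN(c2ccc(-n3cc(-c4ccccn4)cn3)c(F)c2)C(=O)O1)C(F)F` differs from compound 3 by (difluoromethyl)carbonyl in place of dimethylsulfamoyl on an amine nitrogen. Within the data shown here, no measured step covers this particular change; the two readable steps both end at compound 3 and both go to lower numbers, so compound 3 stands as the lowest value shown. Leaving its dimethylsulfamoyl group removes the one substituent tied to a readable number, and a return towards the limit region in which compounds 1 and 2 sit is plausible, though nothing directly establishes the direction. The step is therefore expected to be a 1.6-fold higher number from compound 3 to compound 4 (0.20 log units; within the scatter), a modest rise. Compound 4 in this assay is expected to give 250 ug/mL, with a range from 100 ug/mL to 500 ug/mL.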

Compound 4, half-maximal inhibitory concentration: > 400 ug/mL
Compound 4: a limit, no number; the forecaster's own chance of this, stated with the estimate: 45%; middle value at least 1.6-fold (0.20 log units) from the limit.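

Exchanging dimethylsulfamoyl for (difluoromethyl)carbonyl on the amine nitrogen is an at least 2.5-fold higher number from compound 3 to compound 4 (0.40 log units; beyond the scatter) in this assay, which is beyond the scatter for this read-out. The earlier readable steps replaced the whole group on the saturated chain carbon, whereas here the amine nitrogen stays in place and only its substituent changes, so the lower number of compound 3 goes with the dimethylsulfamoyl group and not with an amine nitrogen at this position as such. The steps to compound 4 from compound 1 and from compound 2 cannot be read, since all three compounds stand at one limit: the limit of > 400 ug/mL in this assay, at which 3 of the 4 values shown sit.

From the compounds shown here alone, how compounds 1, 2 and 4 rank beyond that limit stays open, and so does the full size of the rise from compound 3. Also open, going by these compounds, is whether the lower number needs the whole dimethylsulfamoyl group or only part of it, a question that a methylsulfonyl group on the same amine nitrogen could address, while an acetyl group there would show whether the two fluorines of (difluoromethyl)carbonyl matter to the result.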